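The source may report more compounds than this note shows. Statements on the series, on what has been measured and on what is new or still open speak of the compounds shown alone.

Series notes, aryl variation on the shared core.

In a functional assay on NCI-H1975 cells (Homo sapiens) for cytotoxicity, read by CCK-8 assay, with a stated time of 72 h (on this read-out lower numbers stand for stronger inhibition and higher numbers for weaker inhibition), compound 1 `C=CCn1c(=O)/c(=C\c2cccc(Cl)c2Cl)[nH]c(=O)/c1=C\c1ccccc1OC` gives 4500 nM. In this assay compound 2 `C=CCn1c(=O)/c(=C\c2cc(F)ccc2C)[nH]c(=O)/c1=C\c1ccccc1OC` gives 7300 nM. Within the data shown here, the one step between them, a 1.6-fold higher number from compound 1 to compound 2 (0.21 log units; within the scatter), is an exchange of the aryl group on the double-bonded chain carbon bound to an aromatic carbon. Among the two numbers available, compound 2 holds the higher one, though its gap to compound 1 does not exceed the scatter, so no order between the two can be stated.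

Compound 3 `C=CCn1c(=O)/c(=C\c2cccc(C)c2)[nH]c(=O)/c1=C\c1ccccc1OC` is not yet measured. It differs from compound 2 by 3-methylphenyl in place of 5-fluoro-2-methylphenyl on a double-bonded chain carbon bound to an aromatic carbon. Among the measured compounds shown here, only the step from compound 1 to compound 2 bears on this change, a swap at the same place, and it stayed within the scatter. In this assay compound 3 is therefore expected to show no step beyond the scatter, a 1.2-fold lower number from compound 2 to compound 3 (0.09 log units; within the scatter). The estimate for compound 3 is 6000 nM, with a range from 2500 nM to 15000 nM.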

Compound 3, half-maximal inhibitory concentration: 32800 nM
The estimate for compound 3 lay 5.5-fold (0.74 log units) below the measured number; the whole stated range lies below it.
By their numbers in this assay, from the lowest: compounds 1 and 2 (each within the scatter of the next); then compound 3.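

At the double-bonded chain carbon bound to an aromatic carbon, this assay does respond to the aryl group: the exchange gives a 4.5-fold higher number from compound 2 to compound 3 (0.65 log units; beyond the scatter) and also a 7.3-fold higher number from compound 1 to compound 3 (0.86 log units; beyond the scatter) as the second step beyond the scatter. The earlier exchange, with a 1.6-fold higher number from compound 1 to compound 2 (0.21 log units; within the scatter) as its step, stayed within the scatter, so 3-methylphenyl now sets itself apart from both 2,3-dichlorophenyl and 5-fluoro-2-methylphenyl, and this place is not indifferent to the choice of aryl group. No supporting data bear on the reason for this separation.

Since 5-fluoro-2-methylphenyl and 3-methylphenyl differ in more than one feature, the compounds shown do not separate the part played by the fluorine from that of the methyl placement. As far as these compounds go, whether a plain phenyl, a 2-methylphenyl, or an aryl group carrying an amine or a carboxylic acid would follow either level remains open.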